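Working notes: from compound 1 to compound 4

The compounds below may be only part of what the source reports. "The series", "measured", "known", "first", "only" and "open" are said of these compounds alone.

compound 1 `Cc1cc(O)c(C(=O)/C=C/c2ccccc2F)c(=O)o1`: > 100000 nM
compound 2 `Cc1cc(O)c(C(=O)/C=C/c2ccc(F)cc2F)c(=O)o1`: 80300 nM
compound 3 `COc1cc(/C=C/C(=O)c2c(O)cc(C)oc2=O)cc(OC)c1OC`: > 100000 nM

All three values come from a functional assay on HCT-116 cells (Homo sapiens) for cytotoxicity, read by MTT assay; on this read-out lower numbers stand for stronger inhibition and higher numbers for weaker inhibition. Compound 1 gives > 100000 nM, which is a limit and not a number. Compound 1 therefore stands at the limit of > 100000 nM in this assay, at which 2 of the 3 values shown sit. Among the compounds with values here, compound 2 gives 80300 nM, the one actual number in the set.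

The next compound to be measured is compound 4 `COc1ccccc1/C=C/C(=O)c1c(O)cc(C)oc1=O`, and the change from compound 1 is methoxy in place of fluoro on an aromatic carbon, ortho to a large group. Within the data shown here, no measured step covers this exchange. Among the measured compounds shown here, the only measured step is an at least 1.2-fold lower number from compound 1 to compound 2 (0.09 log units; that floor lies within the scatter), with fluoro in place of hydrogen on an aromatic carbon, so it bears on the present change only indirectly.

Compound 3 also carries methoxy groups and gives > 100000 nM, again a limit. With that value as the closest reference, no step beyond the scatter is expected, in either direction, and compound 4 is likely to read as a limit as well. The expected size is an estimated a number no higher from compound 1 to compound 4 (the limit leaves the size open). For compound 4 the estimate is 100000 nM, with an expected range of 50000 nM to 200000 nM.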

Compound 4, half-maximal inhibitory concentration: > 100000 nM
Compound 4 was reported as a limit; the forecaster's own chance of this, stated with the estimate: 70%; the middle value sits exactly at the limit.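

Compound 1 and compound 4 are both reported as limits, and no step between them can be read: the limit of > 100000 nM in this assay, at which 3 of the 4 values shown sit.

The compounds shown leave open whether methoxy in place of fluoro on an aromatic carbon, ortho to a large group, changes the read-out at all, and in which direction.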